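Ring in place of chain on the ether side

The source may hold more compounds than are shown below. What is called first, only, known or untested is meant among the compounds shown, and "the series" means these compounds.

Compound 3 `CCCCCOCNc1n[n+]([O-])c2ccccc2[n+]1[O-]` gives the lowest number among the three measured in a functional assay on KB cells (Homo sapiens) for cytotoxicity, read by MTT assay, with a stated time of 72 h (on this read-out higher numbers stand for weaker inhibition and lower numbers for stronger inhibition), with 1220 nM; compound 2 `COCNc1n[n+]([O-])c2ccccc2[n+]1[O-]` at 1580 nM stands within the scatter of it, while compound 1 `[O-][n+]1nc(NCOC2CCCCC2)[n+]([O-])c2ccccc21` at 4390 nM stands clearly higher. Compound 4 `[O-][n+]1nc(NCOCc2ccccc2)[n+]([O-])c2ccccc21` differs from compound 3 by phenyl in place of butyl on a saturated chain carbon bound to an oxygen on a saturated carbon. Among the measured compounds shown here, two measured steps bear on this. The step of a 1.3-fold lower number from compound 2 to compound 3 (0.11 log units; within the scatter) shows that adding chain carbons at this place changed little. The step of a 3.6-fold lower number from compound 1 to compound 3 (0.56 log units; beyond the scatter), a saturated ring against a chain, moved the number beyond the scatter, upward. For the measured compounds named here, a ring entering again suggests a small rise, though an aromatic ring has no precedent. Compound 4 is therefore expected at 2000 nM, within 800 nM to 5000 nM. That estimate means a 1.6-fold higher number from compound 3 to compound 4 (0.21 log units; within the scatter).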

Compound 4, half-maximal inhibitory concentration: 5720 nM
Compound 4: the middle estimate sits 2.9-fold (0.46 log units) below what was measured; measured number above the stated range.
By their numbers in this assay, from the lowest: compounds 3 and 2 (each within the scatter of the next); then compounds 1 and 4 (each within the scatter of the next).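

In this assay an aromatic ring at this place proves no milder than the saturated one, giving a 4.7-fold higher number from compound 3 to compound 4 (0.67 log units; beyond the scatter) and a 3.6-fold higher number from compound 2 to compound 4 (0.56 log units; beyond the scatter) against only a 1.3-fold higher number from compound 1 to compound 4 (0.11 log units; within the scatter) when benzyl replaces cyclohexyl. The two ring-bearing ethers, compounds 1 and 4, thus sit apart from the methyl and pentyl ethers, compounds 2 and 3, so a ring here, saturated or aromatic, goes with the higher number. On these data alone, whether a chain longer than pentyl, or a benzyl bearing an amine or a carboxylic acid, falls with the chains or the rings remains open. No measured evidence gives a cause for this split.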